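Rearranging the ester side chain of compound 3

A few compounds are considered here, and "the series" means these few. Any claim that something is new, unique, unknown or untested is made for them only; others in the source may bear on it.

In an ADME assay on HEK-293T cells (Homo sapiens) for cytotoxicity, read by MTT assay, with a stated time of 48 h (a higher number here means that more compound is tolerated, a lower number that less compound is tolerated), the measured compounds read as follows.

- compound 1 `CN(C)CC(=O)O[C@@H]1C[C@@H]2CC[C@@]1(C)C2(C)C` gives 389000 nM
- compound 2 `CN(C)CCC(=O)O[C@@H]1C[C@@H]2CC[C@@]1(C)C2(C)C` gives 505000 nM
- compound 3 `CN(C)CCCC(=O)O[C@@H]1C[C@@H]2CC[C@@]1(C)C2(C)C` gives 101000 nM

Compound 3 has the lowest number of the three, so it is the least tolerated so far. Compound 4 `CCN(CC)CC(=O)O[C@@H]1C[C@@H]2CC[C@@]1(C)C2(C)C` has the same atoms as compound 3, joined differently (diethylamino in place of 2-(dimethylamino)ethyl on a saturated chain carbon bound to a carbonyl carbon). Diethylamino stands in place of 2-(dimethylamino)ethyl on a saturated chain carbon bound to a carbonyl carbon.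

Going by the values given here, three measured steps bear on this change. The first is a 1.3-fold higher number from compound 1 to compound 2 (0.11 log units; within the scatter) and stays within the scatter. The other two are a 3.9-fold lower number from compound 1 to compound 3 (0.59 log units; beyond the scatter) and a 5.0-fold lower number from compound 2 to compound 3 (0.70 log units; beyond the scatter) and are both modest. Among the compounds with values here, the low number thus appears only in compound 3, the one compound carrying 2-(dimethylamino)ethyl at that place. Compound 4 gives up that group and, like compound 1, has its amino group directly on that chain carbon. Within the data shown here, no measured step shows what replacing dimethylamino with diethylamino does, so the expectation stays loose. In this assay the expected change is a 2.5-fold higher number from compound 3 to compound 4 (0.39 log units; beyond the scatter) as a modest rise. For compound 4 the estimate is 250000 nM with an expected range of 110000 nM to 520000 nM as its likely span.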

Compound 4, half-maximal cytotoxic concentration: 344000 nM
Estimate against measurement, compound 4: 1.4-fold (0.14 log units) below, and the stated range covers the measured number.
By their numbers in this assay, from the lowest: compound 3; then compounds 4, 1 and 2 (each within the scatter of the next).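

In this assay, rearranging the same carbon and nitrogen atoms from 2-(dimethylamino)ethyl into diethylamino on a saturated chain carbon bound to a carbonyl carbon gives a 3.4-fold higher number from compound 3 to compound 4 (0.53 log units; beyond the scatter), so the low number of compound 3 does not follow from the size or atom count of the group alone. Going by these compounds alone, the other two new steps, a 1.1-fold lower number from compound 1 to compound 4 (0.05 log units; within the scatter) and a 1.5-fold lower number from compound 2 to compound 4 (0.17 log units; within the scatter), are both within the scatter, and the first of them is the first direct look at diethylamino in place of dimethylamino: at this place, the two ethyl groups on the nitrogen leave the number indistinguishable from that with two methyl groups. Nothing measured here explains why two groups of identical atoms give numbers that differ beyond the scatter.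

The compounds shown leave open whether the low number of compound 3 is tied to the longer chain between carbonyl and nitrogen, whatever the amine, since diethylamino appears only on the shortest chain. They also leave open how a ring amine such as piperidine or morpholine, or a longer chain still, would read at this place.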